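Swapping Dipropylamino for Piperidinyl on the Shared Core

The source may report more compounds than this note shows. Statements on the series, on what has been measured and on what is new or still open speak of the compounds shown alone.

Compound 3 `CCCN(CCC)c1ccc(Nc2ncc(Cl)c(Oc3cccc(NC(=O)CC)c3)n2)c(OC)c1` was tested in an assay on isolated protein for inhibition of NUAK family SNF1-like kinase 2 (Homo sapiens), read by ADP-Glo, with a stated time of 60 min, tested at 10 uM, in the presence of a further agent that is not named here (on this read-out lower numbers stand for less inhibition and higher numbers for more inhibition at the one concentration tested (going by the name of the read-out)), where compound 3 gave "not active" (no number reported), so no single number stands for it. Compound 1 `CCCN(CCC)c1ccc(Nc2ncc(Cl)c(Oc3cccc(NC(=O)CC)c3)n2)cc1` likewise gave "not active" (no number reported) in this assay. Only compound 2 `CCC(=O)Nc1cccc(Oc2nc(Nc3ccc(N(CC)CC)cc3)ncc2Cl)c1` yielded a number, as compound 2 gave 21.2% in this assay. Compound 4 `CCC(=O)Nc1cccc(Oc2nc(Nc3ccc(N4CCCCC4)cc3OC)ncc2Cl)c1` differs from compound 3 in one place: piperidin-1-yl in place of dipropylamino on an aromatic carbon. Among the measured compounds shown here, no measured pair shows what this change does, so the step from compound 3 to compound 4 in this assay is expected to stay within the usual scatter, with no clear direction. Compound 4 is therefore expected to give 8% in this assay, within a range from 0% to 28%, with a real chance that again only an inactive call and no number is reported.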

Compound 4, a percentage reported as inhibition, at one concentration (the size of the read-out at that concentration, not a potency): "not active" (no number reported)
Nothing numeric was reported for compound 4; there is nothing to compare the estimate with.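

Compound 3 and compound 4 were both called inactive with no number, so no step can be read between them. No evidence here bears on this result. Going by these compounds, whether swapping dipropylamino for piperidin-1-yl changes inhibition at all stays open.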